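Shared core phosphatase series: removing the amide side chain

The source may hold more compounds than are shown below. What is called first, only, known or untested is meant among the compounds shown, and "the series" means these compounds.

Measured so far:
compound 1 `CCN(CC)C(=O)COc1ccc2cc(C(O)(C(F)(F)F)C(F)(F)F)c(O)cc2c1` — > 20000 nM
compound 2 `CCCNC(=O)COc1ccc2cc(C(O)(C(F)(F)F)C(F)(F)F)c(O)cc2c1` — > 20000 nM
compound 3 `O=C(COc1ccc2cc(C(O)(C(F)(F)F)C(F)(F)F)c(O)cc2c1)NC1CC1` — > 20000 nM

In an assay on isolated protein for inhibition of receptor-type tyrosine-protein phosphatase C (Homo sapiens), read by spectrophotometry (on this read-out higher numbers stand for weaker inhibition and lower numbers for stronger inhibition), compound 1 is reported only as a limit, > 20000 nM. Compound 2 likewise returns a limit, > 20000 nM. Compound 3 also gives a limit, > 20000 nM, so its position on the numbers is known only as this bound. Going by the values given here, the three measured steps are therefore unreadable: a step that the two limits leave unreadable from compound 1 to compound 2, a step that the two limits leave unreadable from compound 1 to compound 3 and a step that the two limits leave unreadable from compound 2 to compound 3, all because of the limit of > 20000 nM in this assay, at which 3 of the 3 values shown sit, at which every value of the series so far sits.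

Compound 4 `Oc1cc2ccccc2cc1C(O)(C(F)(F)F)C(F)(F)F` carries the change (hydrogen in place of (cyclopropylcarbamoyl)methoxy on an aromatic carbon). Among the compounds with values here, none of the measured steps touches this position, and none gives a readable size, so there is no measured basis for a direction. Compound 4 is expected to give a limit again, with an estimate of 30000 nM in this assay. The expected range for compound 4 runs from 10000 nM to 100000 nM. The expected step from compound 3 to compound 4 is thus a step that the limit leaves unreadable from compound 3 to compound 4, none beyond the scatter.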

Compound 4, half-maximal inhibitory concentration: 112000 nM
For compound 4 the middle estimate is 3.7-fold (0.57 log units) below the measured one; measured number outside the range, above it.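

Going by these compounds alone, no step from compound 1, compound 2 or compound 3 to compound 4 can be read, because each of those three compounds gives only a limit: the limit of > 20000 nM in this assay, at which 3 of the 4 values shown sit. The compounds shown leave open the direction and size of the change in this assay when hydrogen replaces these side chains.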